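Compound 2 and an unmeasured butoxy analogue

A few compounds are considered here, and "the series" means these few. Any claim that something is new, unique, unknown or untested is made for them only; others in the source may bear on it.

Compound 1 `Cc1nn(C)c2nc(NNC(=O)Nc3cc(Cl)nc(Cl)c3)cc(C3CC3)c12`, 67700 nM
Compound 2 `CCN(CC)c1cc(NC(=O)NNc2cc(-c3ccc(F)cc3)c3cnn(C)c3n2)cc(Cl)n1`, 29400 nM
Compound 3 `CCCc1cc(NNC(=O)Nc2cc(Cl)nc(Cl)c2)nc2c1cnn2C`, 76200 nM

All three values come from a functional assay on HCT-116 cells (Homo sapiens) for cytotoxicity, read by MTT assay, with a stated time of 48 h, in the presence of a further agent that is not named here; on this read-out lower numbers stand for an effect already at smaller amounts and higher numbers for an effect only at larger amounts of compound. Compound 2 gives the lowest number of the three, 29400 nM, and its gaps to compound 1 and compound 3 lie beyond the scatter. Compound 4 `CCCCOc1cc(NC(=O)NNc2cc(-c3ccc(F)cc3)c3cnn(C)c3n2)cc(Cl)n1` has not yet been measured. It differs from compound 2 in one place: butoxy in place of diethylamino on an aromatic carbon. Within the data shown here, no measured pair shows this change directly, so the data give no firm guide to its size. With the rest of the structure unchanged, compound 4 is expected to stay close to compound 2 at 29400 nM, with no step beyond the scatter in either direction. The expected change is a 1.1-fold lower number from compound 2 to compound 4 (0.04 log units; within the scatter). Compound 4 is estimated at 27000 nM, with an expected range of 11000 nM to 65000 nM.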

Compound 4, half-maximal effective concentration: 49400 nM
For compound 4 the middle estimate is 1.8-fold (0.26 log units) below the measured one, within the range that was stated.
By their numbers in this assay, from the lowest: compounds 2, 4, 1 and 3 (each within the scatter of the next, the first and the last beyond it).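

In this assay the step at this aromatic carbon, next to the ring nitrogen, is a 1.7-fold higher number from compound 2 to compound 4 (0.23 log units; within the scatter). Butoxy in place of diethylamino, two groups of equal heavy-atom count, therefore leaves the read-out within the scatter in this one pair, which is the first direct look at a change at this place. Nothing available here bears on why this is so. On these data alone, whether methoxy, morpholine or a free amine on the same carbon would stay this close to compound 2 remains open.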